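A few compounds are considered here, and "the series" means these few. Any claim that something is new, unique, unknown or untested is made for them only; others in the source may bear on it.

The measured compounds:
compound 1 `CC(C(=O)NCc1ccc(C(F)(F)F)nc1Nc1ccccc1)c1ccc(NS(C)(=O)=O)c(F)c1` gives 1400 nM
compound 2 `CC(C(=O)NCc1ccc(C(F)(F)F)nc1N1CCC(Cc2ccc(F)c(F)c2)CC1)c1ccc(NS(C)(=O)=O)c(F)c1` gives 30 nM
compound 3 `CC(C(=O)NCc1ccc(C(F)(F)F)nc1N1CCC(C(=O)c2ccc(F)cc2)CC1)c1ccc(NS(C)(=O)=O)c(F)c1` gives 990 nM

All three were tested in a functional assay on CHO-K1 cells for antagonist activity at transient receptor potential cation channel subfamily V member 1 (Homo sapiens), read by FLIPR; a lower number here means a stronger inhibitor, a higher number a weaker inhibitor. Compound 1 stands at the highest of the three numbers; compound 3 sits close to it, within the scatter, while compound 2 lies far lower, beyond it. Within the two piperidine-bearing compounds the one measured step is large: a 33-fold higher number from compound 2 to compound 3 (1.52 log units; beyond the scatter). Compound 4 `CC(=O)OC1CCN(c2nc(C(F)(F)F)ccc2CNC(=O)C(C)c2ccc(NS(C)(=O)=O)c(F)c2)CC1` has not yet been measured. It differs from compound 1 in one place: 4-acetoxypiperidin-1-yl in place of anilino on an aromatic carbon. For the measured compounds named here, no measured step bears on this change directly. Going by the values given here, the only compounds in which a piperidinyl ring replaces the anilino group, compound 2 and compound 3, differ from each other in what sits on the saturated ring carbon, and they span a wide range in this assay. The acetoxy group of compound 4 resembles neither the 3,4-difluorobenzyl of compound 2 nor the (4-fluorophenyl)carbonyl of compound 3. For compound 4 the expected step is therefore a 1.8-fold lower number from compound 1 to compound 4 (0.24 log units; within the scatter), a modest shift carrying wide uncertainty. Compound 4 is estimated at 800 nM, with a range from 150 nM to 4000 nM.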

Compound 4, half-maximal inhibitory concentration: 139 nM
For compound 4 the middle estimate is 5.8-fold (0.76 log units) above the measured one; measured number below the stated range.
By their numbers in this assay, from the lowest: compound 2; then compound 4; then compounds 3 and 1 (each within the scatter of the next).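

In this assay, 4-acetoxypiperidin-1-yl in place of anilino on this aromatic carbon gives a 10-fold lower number from compound 1 to compound 4 (1.00 log units; beyond the scatter) at this place next to the ring nitrogen, so a piperidine here need not carry an aromatic ring on its saturated ring carbon to stand clearly apart from compound 1. On that saturated ring carbon, acetoxy in place of (4-fluorophenyl)carbonyl gives a 7.1-fold lower number from compound 3 to compound 4 (0.85 log units; beyond the scatter) and acetoxy in place of 3,4-difluorobenzyl gives a 4.6-fold higher number from compound 2 to compound 4 (0.67 log units; beyond the scatter) in the other direction, placing compound 4 between the two earlier piperidines. Compound 3 and compound 4 both hold a carbonyl in that substituent, yet they stand apart, so a carbonyl alone does not set the number. Nothing measured here accounts for these steps. Still open, from the compounds shown here alone, is how a hydroxyl, an amine or a carboxylic acid on that saturated ring carbon would compare with acetoxy.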